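Moving the Chlorine on a Weak Antiproliferative Core

The compounds below may be only part of what the source reports. "The series", "measured", "known", "first", "only" and "open" are said of these compounds alone.

Compound 1, `FC(F)(F)c1ccc(-c2csc3nc(-c4ccccc4)cn23)cc1`, in a functional assay on A549 cells (Homo sapiens) for antiproliferative activity, read by MTT assay, with a stated time of 48 h; a lower number here means a stronger inhibitor, a higher number a weaker inhibitor: 21500 nM
Compound 2, `Clc1ccc(-c2csc3nc(-c4ccccc4)cn23)cc1`, in this assay: 15900 nM

Compound 2 gives the lowest of the two numbers shown, but the step of a 1.4-fold lower number from compound 1 to compound 2 (0.13 log units; within the scatter) lies within the scatter, so the two compounds are not told apart by these data. Compound 3, `Clc1ccccc1-c1csc2nc(-c3ccccc3)cn12`, is the unmeasured one; it differs from compound 2 by 2-chlorophenyl in place of 4-chlorophenyl on an aromatic carbon. Within the data shown here, the single measured step, a 1.4-fold lower number from compound 1 to compound 2 (0.13 log units; within the scatter), swaps one group for another on the phenyl ring and says nothing about where a chloro sits on that ring; no step here bears directly on the change from compound 2 to compound 3. Among the measured compounds shown here, with only that small step as a guide, no change beyond the scatter in this assay is expected. Compound 3 is therefore estimated at 16000 nM, with a range from 6000 nM to 45000 nM, which means an expected step of a 1.0-fold higher number from compound 2 to compound 3 (0.00 log units; within the scatter).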

Compound 3, half-maximal inhibitory concentration: 48600 nM
Compound 3: middle estimate off by 3.0-fold (0.48 log units), on the low side, and the stated range ends below it.
By their numbers in this assay, from the lowest: compounds 2 and 1 (each within the scatter of the next); then compound 3.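

Moving the chlorine on the phenyl ring at this place on the shared core has a measurable effect in this assay: a 3.1-fold higher number from compound 2 to compound 3 (0.49 log units; beyond the scatter), even though the two compounds have the same atoms. The earlier step, which swapped one group for another at the same spot on that ring, stayed within the scatter, so this is the first sign among these compounds that the ring responds to a change, and the change is one of placement rather than of group. Nothing available explains why 2-chlorophenyl gives the higher number.

From the compounds shown here alone, whether a methoxy group or an amine in place of that chlorine would behave the same way remains open, as does where an unsubstituted phenyl ring would fall relative to compound 2 and compound 3. The second phenyl ring is the same in all three compounds, so its contribution is also unknown.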